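The compounds below may be only part of what the source reports. "The series", "measured", "known", "first", "only" and "open" are said of these compounds alone.

Measured in a functional assay on MGC-803 cells (Homo sapiens) for antiproliferative activity, read by CellTiter-Glo, with a stated time of 72 h; a lower number here means a stronger inhibitor, a higher number a weaker inhibitor:
- compound 1 `O=C(NO)c1ccc(/C=C/c2cc(-c3ccc(C(F)(F)F)cc3)ncc2F)cc1`: > 10000 nM (a limit)
- compound 2 `Cc1ccc(-c2cncc(/C=C/c3ccc(C(=O)NO)cc3)c2)cc1`: > 10000 nM (a limit)
- compound 3 `O=C(NO)c1ccc(/C=C/c2cncc(-c3ccc(C(F)(F)F)cc3)c2)cc1`: > 10000 nM (a limit)

Compound 2 is known only as a limit, > 10000 nM. The same holds across the series: the limit of > 10000 nM in this assay, at which 3 of the 3 values shown sit.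

The next compound is compound 4 `O=C(NO)c1ccc(/C=C/c2cncc(-c3ccccc3O)c2)cc1`. The change is 2-hydroxyphenyl in place of 4-methylphenyl on an aromatic carbon, meta to a large group.

Within the data shown here, the only measured step that bears on this change is a step that the two limits leave unreadable from compound 2 to compound 3, with trifluoromethyl in place of methyl on an aromatic carbon. That step has no readable size. The series therefore gives no measured size or direction to carry over, and no step beyond the scatter is expected in this assay. Another limit is the likeliest reading.

The estimated change is a number no higher from compound 2 to compound 4 (the limit leaves the size open). Compound 4 is expected at 10000 nM, with an estimated range from 3000 nM to 30000 nM.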

Compound 4, half-maximal inhibitory concentration: 5460 nM
Estimate against measurement, compound 4: 1.8-fold (0.26 log units) above; the range from low to high includes it.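

Compound 4 is the only compound shown that reads as a number rather than a limit in this assay: the limit of > 10000 nM in this assay, at which 3 of the 4 values shown sit. At this aromatic carbon, two atoms from the ring nitrogen, 2-hydroxyphenyl in place of 4-methylphenyl gives an at least 1.8-fold lower number from compound 2 to compound 4 (0.26 log units; that floor lies within the scatter). From the compounds shown here alone, the true size of the step stays open, as compound 2 is known only as a limit, but this position can carry a group that brings the read-out into the measurable range.

Still open, going by these compounds, is whether the hydroxyl itself or its place on the phenyl ring accounts for the readable value. Also open, on these data alone, is whether 2-methoxyphenyl or 2-aminophenyl at this carbon would likewise give a number rather than a limit.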